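The source may hold more compounds than are shown below. What is called first, only, known or untested is meant among the compounds shown, and "the series" means these compounds.

Compound 1 `O=C(Nc1cccc(-n2cc(-c3ccncc3)c(-c3cc(O)cc(Cl)c3)n2)c1)Nc1ccc(Cl)c(Cl)c1` and compound 2 `COc1cc(Cl)cc(-c2nn(-c3cccc(NC(=O)Nc4cc(C(F)(F)F)cc(C(F)(F)F)c4)c3)cc2-c2ccncc2)c1` were both tested in a functional assay on UACC-62 cells (Homo sapiens) for inhibition, read by sulforhodamine B assay, with a stated time of 48 h, tested at 100 uM; a lower number here means a stronger effect, a higher number a weaker effect of the compound at the concentration tested. Compound 1 gives -74%, the lowest of the two numbers, and compound 2 gives -71%, which lies within the scatter of that reading. Compound 3 `COc1cc(Cl)cc(-c2nn(-c3cccc(NC(=O)Nc4ccc(Cl)c(Cl)c4)c3)cc2-c2ccncc2)c1` is one change away from compound 1: methyl in place of hydrogen on an oxygen on an aromatic ring. Among the compounds with values here, no measured pair shows this change on its own, yet compound 2 already carries the methoxy and sits close to compound 1, so the change is expected to bring a step of a number 2 percentage points higher from compound 1 to compound 3 (within the scatter), none beyond the scatter. Compound 3 is therefore estimated at -72% in this assay, between -88% and -52%.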

Compound 3, a percentage reported as activity, at one concentration (the size of the read-out at that concentration, not a potency): -32%
The estimate for compound 3 lay 40 percentage points below the measured number; measured number above the stated range.
By their numbers in this assay, from the lowest: compounds 1 and 2 (each within the scatter of the next); then compound 3.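

In this assay, methyl in place of hydrogen on this aromatic oxygen, hydroxy to methoxy, brings a number 42 percentage points higher from compound 1 to compound 3 (beyond the scatter), so this position is sensitive to the change when the rest of compound 1 is held fixed. The methoxy does not settle the reading on its own: compound 2 also carries it and gives -71%. The compounds shown offer no measurement that explains the step. From the compounds shown here alone, it remains open how an amine or an ethoxy group would read at this position, and how the hydroxy would read on the scaffold of compound 2.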